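Compound 1 to compound 4: nitro replaced by methoxycarbonyl

The compounds below may be only part of what the source reports. "The series", "measured", "known", "first", "only" and "open" are said of these compounds alone.

Three compounds have a reading so far in a functional assay on MGC-803 cells (Homo sapiens) for inhibition, read by MTT assay, with a stated time of 48 h (a lower number here means a stronger inhibitor, a higher number a weaker inhibitor), to anchor this step. Compound 1 (`COc1ccc(CNc2cc(OC)c(OC)c(OC)c2)cc1[N+](=O)[O-]`) gives 19400 nM as the higher of the two numeric values. Compound 2 (`CCCCC(=O)N(Cc1ccc(OC)c(O)c1)c1cc(OC)c(OC)c(OC)c1`) gives 66 nM as its value, lower than that of compound 1 by far more than the scatter. Compound 3 (`COc1cc(NCc2ccc(Cl)cc2)cc(OC)c1OC`) returns > 80000 nM and this is a limit of this assay and not a number. Compound 1 therefore stands well away from compound 2 while still giving a number.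

Compound 4 (`COC(=O)c1cc(CNc2cc(OC)c(OC)c(OC)c2)ccc1OC`) keeps the core of compound 1 and carries one change (methoxycarbonyl in place of nitro on an aromatic carbon): methoxycarbonyl in place of nitro on an aromatic carbon, ortho to a methoxy group and meta to a large group. Among the compounds with values here, no measured pair in the set differs in one place, so this swap has no direct precedent. The closest anchor is compound 1 at 19400 nM and on that basis no change beyond the scatter is expected in this assay in either direction. The expected move (a 1.3-fold higher number from compound 1 to compound 4 (0.11 log units; within the scatter)) is therefore small, though with a wide margin. For compound 4 the estimated half-maximal inhibitory concentration is 25000 nM with an expected range of 7000 nM to 80000 nM around it.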

Compound 4, half-maximal inhibitory concentration: 49600 nM
Compound 4: middle estimate off by 2.0-fold (0.30 log units), on the low side; the range from low to high includes it.
By their numbers in this assay, from the lowest: compound 2; then compound 1; then compound 4. At a limit, above all of these: compound 3.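

Methoxycarbonyl in place of nitro on an aromatic carbon, ortho to a methoxy group and meta to a large group, gives a 2.6-fold higher number from compound 1 to compound 4 (0.41 log units; beyond the scatter) in this assay, the first step in the series that isolates a change at one place. The step is modest but beyond the scatter, and it appears although the two groups match in hydrogen-bond donors, hydrogen-bond acceptors and net charge, so those counts alone do not set the reading at this position. Compound 3 holds the one value that is a limit and not a number: the limit of > 80000 nM in this assay, at which 1 of the 4 values shown sits.

A single swap leaves open whether the weaker reading is specific to methoxycarbonyl or would follow other replacements of nitro on this aromatic carbon, and a carboxylic acid, an amine or a longer alkoxycarbonyl chain there would help to separate these cases. One pair at one place in one assay also leaves open whether a step of this size and direction would hold on a compound that differs elsewhere from the core of compound 1.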